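Swapping the aryl ketone substituent of a trimethoxyphenyl pyrazole chalcone

A few compounds are considered here, and "the series" means these few. Any claim that something is new, unique, unknown or untested is made for them only; others in the source may bear on it.

Measured so far:
compound 1 `COc1cc(-c2cc(/C=C/C(=O)c3ccc(N)cc3)[nH]n2)cc(OC)c1OC` gives 57%
compound 2 `COc1ccc(C(=O)/C=C/c2cc(-c3cc(OC)c(OC)c(OC)c3)n[nH]2)cc1` gives 83%

Both compounds share a core carrying a 3,4,5-trimethoxyphenyl group and a pyrazole joined through an enone to a second aromatic ring, and both were tested in a functional assay on KM12 cells (Homo sapiens) for cytotoxicity, read by sulforhodamine B assay, with a stated time of 48 h, tested at 1 uM; a higher number here means a weaker effect of the compound at the concentration tested, a lower number a stronger effect. Among the compounds with values here, compound 2 gives the highest of the two numbers in this assay, that is the weaker effect at the concentration tested, and the step of a number 26 percentage points higher from compound 1 to compound 2 (beyond the scatter) is the single measured step here.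

Compound 3 `COc1cc(-c2cc(/C=C/C(=O)c3ccc(F)c(F)c3)[nH]n2)cc(OC)c1OC` is the next compound. It differs from compound 2 in one place: 3,4-difluorophenyl in place of 4-methoxyphenyl on a carbonyl carbon. Within the data shown here, the measured step concerns an amino and a methoxy group on that same aromatic ring, so it shows only that this ring is a place where a change can move the number by a modest amount; it says nothing about a fluorine-bearing ring. Among the measured compounds shown here, with no direct precedent, the expected step of a number 5 percentage points lower from compound 2 to compound 3 (within the scatter) is small, without a clear direction, and may well stay within the scatter. Compound 3 is therefore estimated at 78%, in a range from 55% to 100%.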

Compound 3, a percentage reported as activity, at one concentration (the size of the read-out at that concentration, not a potency): 95%
Compound 3: middle estimate off by 17 percentage points, on the low side, and the stated range covers the measured number.
By their numbers in this assay, from the lowest: compound 1; then compound 2; then compound 3.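

In this assay, putting 3,4-difluorophenyl in place of 4-methoxyphenyl on the carbonyl carbon gives a number 12 percentage points higher from compound 2 to compound 3 (beyond the scatter) and so extends the picture from the amino and methoxy pair to a ring with fluorine on it, where the effect at the concentration tested becomes weaker still. Within the data shown here, measured against the 4-aminophenyl group, the same ring gives a number 38 percentage points higher from compound 1 to compound 3 (beyond the scatter) and this is the largest step so far, which leaves compound 3 with the weakest effect of the three and compound 1 with the strongest. The three groups on this carbonyl carbon are now all separated beyond the usual scatter, but no measurement at hand explains their order.

Open questions remain about how far the amino group can be varied, for example whether a dimethylamino or an acetamide group on the same ring, or a hydroxyl group in its place, would keep the stronger effect of compound 1. Going by these compounds, it is also open whether a single fluorine would behave like the 3,4-difluorophenyl group, and how these compounds would rank across a range of concentrations rather than at one.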